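Three Amide Agonists and a Trifluoromethyl Replacement

The source may hold more compounds than are shown below. What is called first, only, known or untested is meant among the compounds shown, and "the series" means these compounds.

Three compounds share a core built from an amide joined to a carbon that carries an aromatic ring and a short chain ending in a dimethylamino group. Compound 1 `COc1ccc(CCC(=O)NC(CCN(C)C)c2ccc3ccccc3c2)cc1` gives 1410 nM in a functional assay on NIH3T3 cells for agonist activity at Urotensin-2 receptor (Homo sapiens), with a stated time of 5 days; on this read-out lower numbers stand for an effect already at smaller amounts and higher numbers for an effect only at larger amounts of compound. Compound 2 `CN(C)CCC(NC(=O)CCc1ccccc1)c1ccc(Cl)cc1` gives 1660 nM in this assay, and compound 3 `Cc1ccc(C(CCN(C)C)NC(=O)/C=C/c2ccccc2)cc1` gives 1550 nM. The gaps between these three numbers are within the usual scatter, so compound 1 stands level with compound 2 and compound 3 rather than apart from them.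

Compound 4 `CN(C)CCC(NC(=O)CCc1ccc(C(F)(F)F)cc1)c1ccc2ccccc2c1` is not yet measured. It differs from compound 1 in one place: trifluoromethyl in place of methoxy on an aromatic carbon, which reads trifluoromethyl in place of methoxy on an aromatic carbon, para to a large group. Among the measured compounds shown here, no measured pair in this set shows what such a change does. With nothing to point either way, the step from compound 1 to compound 4 is expected to be small, a 1.1-fold higher number from compound 1 to compound 4 (0.03 log units; within the scatter), not beyond the scatter. Compound 4 is estimated at 1500 nM, with a range from 500 nM to 4500 nM.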

Compound 4, half-maximal effective concentration: 372 nM
The estimate for compound 4 lay 4.0-fold (0.61 log units) above the measured number; measured number outside the range, below it.
By their numbers in this assay, from the lowest: compound 4; then compounds 1, 3 and 2 (each within the scatter of the next).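

Trifluoromethyl in place of methoxy on an aromatic carbon, para to a large group, gives a 3.8-fold lower number from compound 1 to compound 4 (0.58 log units; beyond the scatter) in this assay, a step beyond the scatter. Compounds 1, 2 and 3 stand level and no two of them differ in only one place, so they gave no sign that the number could move; this pair shows that a single change at this position can shift it. No measurement shown here accounts for the shift.

The compounds shown leave open how other groups on that aromatic carbon, such as a nitrile, a chlorine atom or a carboxylic acid, would compare with trifluoromethyl and methoxy. They also leave open whether the same replacement would move the number on a different core.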